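A few compounds are considered here, and "the series" means these few. Any claim that something is new, unique, unknown or untested is made for them only; others in the source may bear on it.

Working notes on the series.

Compound 3 `Cc1ccc(C(CCN(C)C)NC(=O)CCc2ccccc2)cc1` gives in a functional assay on NIH3T3 cells for agonist activity at Urotensin-2 receptor (Homo sapiens), with a stated time of 5 days (on this read-out higher numbers stand for an effect only at larger amounts of compound and lower numbers for an effect already at smaller amounts), a value of 4570 nM, the highest of the three numbers in hand. Compound 1 `Cc1ccc(C(CCN(C)C)NC(=O)C#Cc2ccccc2)cc1` gives 3090 nM in this assay, and compound 2 `COc1ccc(/C=C/C(=O)NC(CCN(C)C)c2ccc(C)cc2)cc1` gives 2000 nM. The gap from compound 3 to compound 1 lies within the scatter; the gap from compound 3 to compound 2 lies beyond it.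

The next structure is compound 4 `Cc1ccc(C(CCN(C)C)NC(=O)/C=C/c2ccccc2)cc1`. Relative to compound 3 the change is 2-phenylethenyl in place of phenethyl on a carbonyl carbon, so the link to the phenyl now carries one double bond outside aromatic rings.

Within the data shown here, only one measured step touches the same position: a 1.5-fold higher number from compound 1 to compound 3 (0.17 log units; within the scatter), which exchanges 2-phenylethynyl for phenethyl and stays within the scatter. Compound 4 sits between those two ends of the series. Compound 2 also carries a 2-phenylethenyl-type link on its carbonyl carbon but differs from compound 4 in a second place as well, so its value is only a loose pointer toward somewhat lower numbers.

Taken together, the expected step is a 1.6-fold lower number from compound 3 to compound 4 (0.21 log units; within the scatter), a slight move toward lower numbers that stays within the scatter. Compound 4 is expected at 2800 nM, with a range from 1200 nM to 6500 nM.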

Compound 4, half-maximal effective concentration: 1550 nM
Estimate against measurement, compound 4: 1.8-fold (0.26 log units) above, within the range that was stated.
By their numbers in this assay, from the lowest: compounds 4, 2, 1 and 3 (each within the scatter of the next, the first and the last beyond it).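

In this assay, among these compounds, a 2.9-fold lower number from compound 3 to compound 4 (0.47 log units; beyond the scatter) is the first step at this carbonyl carbon to lie beyond the scatter, so 2-phenylethenyl and phenethyl, which differ by the one double bond outside aromatic rings, can now be told apart on this read-out. The other two steps do not separate their pairs: a 2.0-fold lower number from compound 1 to compound 4 (0.30 log units; within the scatter), with 2-phenylethenyl in place of 2-phenylethynyl, and a 1.3-fold lower number from compound 2 to compound 4 (0.11 log units; within the scatter), with hydrogen in place of methoxy on an aromatic carbon, both stay within the scatter, and methoxy on that aromatic carbon therefore shows no resolved effect in this pair. Nothing on hand explains why the double-bond link gives a lower number than phenethyl.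

Left open is whether a longer chain in place of 2-phenylethenyl on the carbonyl carbon, or the cis isomer of that group, would hold the value of compound 4 at 1550 nM or move it. Also open, as far as these compounds go, is how a chlorine atom or a hydroxyl group in place of the methoxy of compound 2 would read in this assay, and whether a larger amine in place of the dimethylamino group would shift the number.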